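The source may hold more compounds than are shown below. What is called first, only, known or untested is meant among the compounds shown, and "the series" means these compounds.

Three measured compounds share one core and differ only in the group attached to the chain carbon. Compound 3 is `O=C(O)c1ccc(C(=O)/C(=C\c2ccc(F)c([N+](=O)[O-])c2)SCc2ccc(C(F)(F)F)cc2)cc1`. In a physicochemical assay for solubility (a lower number here means a less soluble compound, a higher number a more soluble compound), compound 3 gives < 1000 ug/mL, which is a limit of the assay rather than a measured number. Compound 1 is `O=C(O)c1ccc(C(=O)/C(=C\c2ccc(F)c([N+](=O)[O-])c2)SCc2ccc(Cl)cc2)cc1`. In this assay compound 1 gives < 1000 ug/mL, again a limit. Compound 2 is `O=C(O)c1ccc(C(=O)/C(=C\c2ccc(F)c([N+](=O)[O-])c2)S(=O)(=O)Cc2ccc(Br)cc2)cc1`. In this assay compound 2 gives < 1000 ug/mL, also a limit. Because every value sits at the limit of < 1000 ug/mL in this assay, at which 3 of the 3 values shown sit, the two steps joining these compounds cannot be sized: the step that the two limits leave unreadable from compound 1 to compound 2 and the step that the two limits leave unreadable from compound 1 to compound 3 both remain unreadable.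

Compound 4 is `O=C(O)c1ccc(C(=O)/C(=C\c2ccc(F)c([N+](=O)[O-])c2)SCc2ccccc2)cc1` and has not yet been measured. It differs from compound 3 in one place: hydrogen in place of trifluoromethyl on an aromatic carbon. Neither of the measured steps bears readably on this change, as both are hidden by the limit. Nothing in the measured values therefore argues for a move in either direction, and the step that the limit leaves unreadable from compound 3 to compound 4 is expected to be small, with compound 4 most likely remaining at the same limit as the others. Compound 4 is expected to come out at about 400 ug/mL, in a range from 50 ug/mL to 1500 ug/mL.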

Compound 4, solubility: < 1000 ug/mL
Compound 4: a limit, no number; the forecaster's own chance of this, stated with the estimate: 75%; the middle value lies beyond the limit too.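

In this assay compound 4 gives < 1000 ug/mL as a limit and not a number. No new step can be read among compound 1, compound 2, compound 3 and compound 4, because all four stop at the same point: the limit of < 1000 ug/mL in this assay, at which 4 of the 4 values shown sit. The compounds shown leave open how soluble each one actually is, and whether any of these changes alters solubility at all.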